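The source may hold more compounds than are shown below. What is called first, only, known or untested is meant among the compounds shown, and "the series" means these compounds.

Within the data shown here, compound 3 `COc1ccc2nc(C)cc(OCC(=O)Nc3c(C)cncc3C)c2c1` is the one compound with a number in a toxicity assay on HepG2 cells (Homo sapiens) for inhibition, read by CellTiter-Glo, with a stated time of 48 h; on this read-out lower numbers stand for stronger inhibition and higher numbers for weaker inhibition: in this assay compound 3 gives 12600 nM. Compound 1 `COc1ccc2nc(C)cc(OCC(=O)Nc3ccc(Cl)cc3Cl)c2c1` reaches only a limit, and in this assay compound 1 gives > 100000 nM. Compound 2 `COc1ccc2nc(C)cc(OCC(=O)Nc3cccnc3)c2c1` also reaches only a limit, and in this assay compound 2 gives > 100000 nM. The step that the two limits leave unreadable from compound 1 to compound 2 cannot be read. The steps of an at least 7.9-fold lower number from compound 1 to compound 3 (0.89 log units; beyond the scatter) and an at least 7.9-fold lower number from compound 2 to compound 3 (0.89 log units; beyond the scatter) are each bounded by the limit of > 100000 nM in this assay, at which 2 of the 3 values shown sit. Compound 4 `COc1ccc2nc(C)cc(OCC(=O)Nc3nccs3)c2c1` differs from compound 3 by 1,3-thiazol-2-yl in place of 3,5-dimethylpyridin-4-yl on an amide-type nitrogen. Among the measured compounds shown here, no measured step carries a thiazole on the amide-type nitrogen, so the expectation for compound 4 rests on two values at the limit and one number, and a step of a 4.0-fold higher number from compound 3 to compound 4 (0.60 log units; beyond the scatter) toward weaker inhibition in this assay is expected. Compound 4 is estimated at 50000 nM, within a range from 12000 nM to 150000 nM.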

Compound 4, half-maximal inhibitory concentration: > 100000 nM
Compound 4: no number, only a limit; the forecaster's own chance of this, stated with the estimate: 50%; at least 2.0-fold (0.30 log units) between middle value and limit.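

On the amide-type nitrogen, 1,3-thiazol-2-yl in place of 3,5-dimethylpyridin-4-yl brings an at least 7.9-fold higher number from compound 3 to compound 4 (0.89 log units; beyond the scatter) in this assay, so a five-membered aromatic ring now joins the six-membered rings of compounds 1 and 2 in giving no number. Compound 4 gives only a limit, and its steps from compounds 1 and 2 cannot be read. Among the groups shown at this place, only the 3,5-dimethylpyridin-4-yl of compound 3 gives a number, and the rest sit at one value: the limit of > 100000 nM in this assay, at which 3 of the 4 values shown sit.

The compounds shown leave open how an unsubstituted pyridin-4-yl or a 3,5-dimethylphenyl group on this nitrogen would read. Either would help tell the two methyl groups of compound 3 from its ring nitrogen.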